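A few compounds are considered here, and "the series" means these few. Any claim that something is new, unique, unknown or untested is made for them only; others in the source may bear on it.

Measured compounds:
compound 1 `CC1=C(C(=O)Nc2ccc(Br)cc2)C(c2ccc(Cl)cc2Cl)N=C(SCc2ccccc2)N1`, 3.6%;
compound 2 `CC1=C(C(=O)Nc2ccc(Br)cc2)C(c2ccc(Cl)cc2Cl)N=C(SCc2ccc(F)cc2)N1`, 7.7%.

In a functional assay on the whole organism (artery, strain albino) with Rattus norvegicus as the target, with a stated time of 30 min, at a dose of 10 mg/kg by the oral route (on this read-out lower numbers stand for less inhibition and higher numbers for more inhibition at the one dose given (going by the name of the read-out)), compound 1 gives 3.6%, the lowest of the two numbers; its nearest neighbour is compound 2, which gives 7.7% in this assay. Within the data shown here, the one step between measured compounds, a number 4.1 percentage points higher from compound 1 to compound 2 (within the scatter), comes from fluoro in place of hydrogen on an aromatic carbon of the benzylsulfanyl group and stays within the scatter. Compound 3 `COc1ccc(C2N=C(SCc3ccccc3)NC(C)=C2C(=O)Nc2ccc(Br)cc2)cc1` is not yet measured. It differs from compound 1 by 4-methoxyphenyl in place of 2,4-dichlorophenyl on a saturated ring carbon. The measured step concerns a different place in the shared core, so nothing measured bears directly on this change. Among the measured compounds shown here, the only step seen is within the scatter, so a step not beyond the scatter is expected here as well, namely a number 1.4 percentage points higher from compound 1 to compound 3 (within the scatter). Compound 3 is therefore expected to give 5% in this assay, between 0% and 18%.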

Compound 3, a percentage reported as inhibition, in the whole organism at one dose (the size of the read-out at that dose, not a potency): 2.6%
For compound 3 the middle estimate is 2.4 percentage points above the measured one; the measured number falls inside the stated range.
By their numbers in this assay, from the lowest: compounds 3, 1 and 2 (each within the scatter of the next).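

In this assay, among these compounds, the group on the saturated ring carbon is now varied for the first time, and 4-methoxyphenyl in place of 2,4-dichlorophenyl gives a small shift (a number 1 percentage points lower from compound 1 to compound 3 (within the scatter)). This position therefore accepts the loss of both chlorine atoms and the arrival of an oxygen and a hydrogen-bond acceptor without any change in the read-out beyond the scatter, so this pair shows no dependence on which of these two aryl groups is present. No evidence is available that would explain this result.

The compounds shown leave open whether a different kind of group on this saturated ring carbon, such as a carboxylic acid, an amine or a longer chain in place of the aryl ring, would move the number beyond the scatter. They also leave open whether any change at this position could raise the inhibition to a clearly higher level at the one dose given.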